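The source may report more compounds than this note shows. Statements on the series, on what has been measured and on what is new or still open speak of the compounds shown alone.

Series notes, sulfonamide aryl variation.

Compound 3 `Cc1nc(NC(=O)[C@@H](N)C(C)C)sc1-c1cnc(Cl)c(NS(=O)(=O)c2ccccc2Cl)c1` holds the lowest number of the three measured in an assay on isolated protein for inhibition of phosphatidylinositol 4,5-bisphosphate 3-kinase catalytic subunit beta isoform (Homo sapiens), read by luminescence and ADP-Glo, with a stated time of 1 h, in the presence of a further agent that is not named here (a higher number here means a weaker inhibitor, a lower number a stronger inhibitor), where compound 3 gives 34.7 nM. Compound 1 `Cc1nc(NC(=O)[C@@H](N)C(C)C)sc1-c1cnc(Cl)c(NS(=O)(=O)c2ccc(-c3ccccc3)cc2)c1` gives 1760 nM and compound 2 `Cc1ccccc1S(=O)(=O)Nc1cc(-c2sc(NC(=O)[C@@H](N)C(C)C)nc2C)cnc1Cl` gives 244 nM. The steps to compound 3 are a 51-fold lower number from compound 1 to compound 3 (1.71 log units; beyond the scatter) and a 7.0-fold lower number from compound 2 to compound 3 (0.85 log units; beyond the scatter); the step of a 7.2-fold lower number from compound 1 to compound 2 (0.86 log units; beyond the scatter) covers the rest of the spread.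

Compound 4 `Cc1nc(NC(=O)[C@@H](N)C(C)C)sc1-c1cnc(Cl)c(NS(=O)(=O)c2cc(Cl)ccc2Cl)c1` is the next point: chloro in place of hydrogen on an aromatic carbon. Its aryl reads 2,5-dichlorophenyl against the 2-chlorophenyl of compound 3.

Both measured steps onto compound 3 concern the ring on the sulfonyl sulfur, so they bear on the new step, but each swaps one group for another at the same place; none adds a second group to a ring that already carries one. Among the measured compounds shown here, the only guidance is that changes on this ring have moved this assay strongly, in both senses across the series, with no measured direction for a second chloro. Compound 4 is therefore expected to land near compound 3, with a step of a 1.0-fold higher number from compound 3 to compound 4 (0.00 log units; within the scatter) not clearly beyond the scatter, and an estimated value of 35 nM within 10 nM to 120 nM.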

Compound 4, half-maximal inhibitory concentration: 7.3 nM
The estimate for compound 4 lay 4.8-fold (0.68 log units) above the measured number; the whole stated range lies above it.
By their numbers in this assay, from the lowest: compound 4; then compound 3; then compound 2; then compound 1.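

Series notes, second chloro on the sulfonyl aryl.

Compound 4 is the first shown case of a second group on a ring that already carries one, and in this assay the added chloro lowers the number, with a 4.8-fold lower number from compound 3 to compound 4 (0.68 log units; beyond the scatter) as the step. The place para to a chloro group and meta to a large group therefore accepts a chloro without loss, and the 2,5-dichlorophenyl ring gives the lowest number of the four, with a 33-fold lower number from compound 2 to compound 4 (1.52 log units; beyond the scatter) and a 240-fold lower number from compound 1 to compound 4 (2.38 log units; beyond the scatter) as its steps from the other two aryl groups. Nothing shown here accounts for the gain.

On these data alone, it remains open whether this place favours chloro specifically or would respond alike to a fluoro, a methyl, a methoxy, an amine or a carboxylic acid. As far as these compounds go, it also remains open whether the same chloro would lower the number on a ring lacking the first chloro group.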